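The source may hold more compounds than are shown below. What is called first, only, known or untested is meant among the compounds shown, and "the series" means these compounds.

In a functional assay on the whole organism with Rattus norvegicus as the target (a higher number here means that more compound is needed for the effect, a lower number that less compound is needed), compound 1 `CCc1nnc(-c2cn3c(C)c(CC)c(OC)nc3n2)o1` gives 50 mg/kg. Compound 2 `CCCc1nnc(-c2cn3c(C)c(CC)c(OC)nc3n2)o1` gives 50 mg/kg, so the two stand level: no change at the digits printed from compound 1 to compound 2 (within the scatter), a step of methyl in place of hydrogen on a saturated chain carbon. Compound 3 `CCc1csc(-c2cn3c(C)c(CC)c(OC)nc3n2)n1` differs from compound 1 in another way: 4-ethyl-1,3-thiazol-2-yl in place of 5-ethyl-1,3,4-oxadiazol-2-yl on an aromatic carbon. Within the data shown here, no measured step touches a change of the aromatic ring, so the only guide is that compound 1 and compound 2 sit together. The expected step is no change at the digits printed from compound 1 to compound 3 (within the scatter), with wide uncertainty. The estimate for compound 3 is 50 mg/kg, within 15 mg/kg to 150 mg/kg.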

Compound 3, minimum effective dose: 50 mg/kg
Beside the measured number, compound 3's estimate shows no gap at the digits printed; measured number inside the range.
By their numbers in this assay, from the lowest: compounds 1, 2 and 3 (each within the scatter of the next).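

Until now only the chain on the ring had changed; here the ring itself changes at this aromatic carbon. In this assay a five-membered aromatic ring with 2 hetero atoms replaces one with 3, and the ethyl group moves with it, giving no change at the digits printed from compound 1 to compound 3 (within the scatter) for this exchange. Nothing available bears on why the two rings stand level.

Open, as far as these compounds go, is whether this position stays flat with a group other than these ethyl-bearing rings, such as a phenyl ring or a carboxylic acid on the aromatic carbon. Also open, from the compounds shown here alone, is the effect of a longer chain on the 1,3-thiazol-2-yl ring.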